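Ring heteroatom swap carried onto a second core

The compounds below may be only part of what the source reports. "The series", "measured", "known", "first", "only" and "open" are said of these compounds alone.

In a functional assay, tested at 100 ug/mL (on this read-out higher numbers stand for a stronger effect at the one concentration tested and lower numbers for a weaker effect), compound 1 `COc1ccc(C2=NN(c3ccccc3)C(c3ccc(C)cc3)C2S(=O)(=O)CC2=NCCO2)cc1` gives 67.7%. Compound 2 `COc1ccc(C2=NN(c3ccccc3)C(c3ccc(C)cc3)C2S(=O)(=O)CC2=NCCS2)cc1` carries a group of 5 heavy atoms (3 carbon, 1 nitrogen, 1 sulfur; one five-membered non-aromatic ring with 2 hetero atoms) in place of a group of 5 heavy atoms (3 carbon, 1 nitrogen, 1 oxygen; one five-membered non-aromatic ring with 2 hetero atoms), on a saturated chain carbon bound to a sulfonyl sulfur and in this assay compound 2 gives 47.9%, a step of a number 19.8 percentage points lower from compound 1 to compound 2 (beyond the scatter). Compound 3 `COc1ccc(C2=NOC(c3ccc(C)cc3)C2S(=O)(=O)CC2=NCCO2)cc1` rests on a different core; the difference between the two cores is not broken down here. In this assay compound 3 gives 70.9%, which lies within the scatter of the value of compound 1. Compound 4 `COc1ccc(C2=NOC(c3ccc(C)cc3)C2S(=O)(=O)CC2=NCCS2)cc1` is compound 3 with a group of 5 heavy atoms (3 carbon, 1 nitrogen, 1 sulfur; one five-membered non-aromatic ring with 2 hetero atoms) in place of a group of 5 heavy atoms (3 carbon, 1 nitrogen, 1 oxygen; one five-membered non-aromatic ring with 2 hetero atoms), on a saturated chain carbon bound to a sulfonyl sulfur, the same change that was made from compound 1 to compound 2, at the same place. On a single prior instance, the step is expected to be a number 18.9 percentage points lower from compound 3 to compound 4 (beyond the scatter), because the earlier instance gave a number 19.8 percentage points lower from compound 1 to compound 2 (beyond the scatter). Compound 4 is therefore expected to give 52% in this assay, estimated to fall between 38% and 66%.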

Compound 4, a percentage reported as activity, at one concentration (the size of the read-out at that concentration, not a potency): 52.6%
The estimate for compound 4 lay 0.6 percentage points below the measured number, and the stated range covers the measured number.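

In this assay, placing the sulfur-containing five-membered ring in place of the oxygen-containing one, on a saturated chain carbon bound to a sulfonyl sulfur, gives a number 18.3 percentage points lower from compound 3 to compound 4 (beyond the scatter), and the same change on the core of compound 1 matches it in size: the same change on two cores in this assay, a number 19.8 percentage points lower (beyond the scatter) from compound 1 to compound 2 and a number 18.3 percentage points lower (beyond the scatter) from compound 3 to compound 4, 1.5 percentage points apart, within the scatter of two such steps

On these two cores, the change carries over with its size and direction intact. Going by these compounds alone, this rests on only two pairs, each read at one concentration. It does not show that the step holds on other cores, and it does not give a potency.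

As far as these compounds go, it remains open how an amine or a carboxylic acid on the same saturated chain carbon would read. From the compounds shown here alone, whether the step persists on a third core is also open.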